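The compounds below may be only part of what the source reports. "The series", "measured", "known", "first", "only" and "open" are said of these compounds alone.

Measured so far:
compound 1 `O=c1c2sc3ncc4cn[nH]c4c3c2ncn1-c1ccc(Cl)cc1` — 37.6 nM
compound 2 `Cc1ccc(-n2cnc3c(sc4ncc5cc[nH]c5c43)c2=O)cc1` — 0.7 nM
compound 3 `O=c1c2sc3ncc4nc[nH]c4c3c2ncn1-c1ccc(Cl)cc1` — 6 nM

These three compounds were tested in a functional assay on CHO cells for antagonist activity at metabotropic glutamate receptor 1 (Homo sapiens), read by FLIPR; a higher number here means a weaker inhibitor, a lower number a stronger inhibitor. Of them, compound 1 stands at the highest number, which in this assay means the weakest inhibitor of the three. The nearest to it is compound 3, whose number is lower by a gap beyond the usual scatter; compound 2 lies furthest away, lower again by a wide margin. Among the measured compounds shown here, compound 2 and compound 3 each differ from compound 1 in more than one place, so no single step between measured compounds can be read from these three.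

Compound 4 `Cc1ccc(-n2cnc3c(sc4ncc5cn[nH]c5c43)c2=O)cc1` has not yet been measured in this assay. It differs from compound 1 in one place: methyl in place of chloro on an aromatic carbon. Chloro and methyl are each a single heavy atom, neither adds a hydrogen-bond donor or acceptor, and neither carries a charge. For the measured compounds named here, the measured compounds offer no pair that isolates this exchange, so the size of the step is uncertain. Compound 2, which carries the methyl, gives 0.7 nM, but it also has a different core, so its number cannot be split between the two differences. The expected step of a 3.1-fold lower number from compound 1 to compound 4 (0.50 log units; beyond the scatter) is a modest move toward a lower number, one that may not clearly exceed the usual scatter. Compound 4 is therefore estimated at 12 nM, with a range from 2.5 nM to 50 nM.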

Compound 4, half-maximal inhibitory concentration: 16.8 nM
Estimate against measurement, compound 4: 1.4-fold (0.15 log units) below, and the stated range covers the measured number.
By their numbers in this assay, from the lowest: compound 2; then compound 3; then compound 4; then compound 1.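

Among the compounds shown here, compound 1 and compound 4 form the first measured pair that isolates the exchange of 4-chlorophenyl for 4-methylphenyl, and in this assay the change gives a 2.2-fold lower number from compound 1 to compound 4 (0.35 log units; beyond the scatter). This step is modest but beyond the usual scatter, so this place on the aromatic ring, para to a large group, does respond to the exchange of one single heavy atom for another, even though the two groups have the same hydrogen-bond donor and acceptor counts and neither carries a charge. No measurement available here explains why the methyl compound gives the lower number.

As far as these compounds go, the same exchange cannot be read on either of the other two cores, since compound 2 carries only the methyl and compound 3 only the chloro, so it remains unknown whether the size of this step carries over from one core to another. Also open, from the compounds shown here alone, is how this place would respond to a group of a different kind, such as methoxy, an amine or a carboxylic acid, or to plain hydrogen, which would show what either group adds to the unsubstituted ring.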